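Adding a hydroxy group to compound 2

The source may hold more compounds than are shown below. What is called first, only, known or untested is meant among the compounds shown, and "the series" means these compounds.

In a functional assay on KB cells (Homo sapiens) for antiproliferative activity, read by sulforhodamine B assay, with a stated time of 48 h (on this read-out lower numbers stand for stronger inhibition of growth and higher numbers for weaker inhibition of growth), compound 2 `COc1ccc(S(=O)(=O)Nc2ccccc2CCc2ccc(C(=O)Nc3ccccc3)cc2)cc1` gives 137 nM, the higher of the two numbers available. Going by the values given here, the only other measured compound, compound 1 `COc1ccc(S(=O)(=O)Nc2ccccc2CCc2ccc(C(=O)Nc3ccccc3N)cc2)cc1`, gives 23 nM, which leaves compound 2 at the weaker end of this short series. Compound 3 `COc1ccc(S(=O)(=O)Nc2ccccc2CCc2ccc(C(=O)Nc3ccccc3O)cc2)cc1` is compound 2 with one change: hydroxy in place of hydrogen on an aromatic carbon. In words, this is hydroxy in place of hydrogen on an aromatic carbon, ortho to a large group, or phenyl to 2-hydroxyphenyl. Among the compounds with values here, the one measured step that bears on this change is hydrogen in place of amino on an aromatic carbon, which gave a 6.0-fold higher number from compound 1 to compound 2 (0.77 log units; beyond the scatter). Within the data shown here, no measured compound carries a hydroxy group, so that step serves only as a rough guide. In this assay, a modest move to a lower number than that of compound 2 is expected, smaller than the step just described and possibly close to the scatter. The estimate amounts to an expected step of a 2.3-fold lower number from compound 2 to compound 3 (0.36 log units; beyond the scatter). The estimated value for compound 3 is 60 nM, within an expected range of 22 nM to 160 nM.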

Compound 3, concentration for 50% growth inhibition: 472 nM
Beside the measured number, compound 3's estimate is 7.9-fold (0.90 log units) below it, outside the stated range (above it).
By their numbers in this assay, from the lowest: compound 1; then compound 2; then compound 3.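

In this assay, hydroxy on this aromatic carbon, ortho to a large group, gives a 3.4-fold higher number from compound 2 to compound 3 (0.54 log units; beyond the scatter) and so moves the number the opposite way from amino, showing that a new group at this position does not by itself bring stronger inhibition of growth. The contrast between the two groups on the same carbon is wider still, with a 21-fold higher number from compound 1 to compound 3 (1.31 log units; beyond the scatter) as the large step of the series, so among the three compounds the order runs amino, then hydrogen, then hydroxy, and the identity of the group here matters more than the step from hydrogen alone had suggested. No measurement given here accounts for why amino and hydroxy part so sharply.

The compounds shown leave open where a methoxy group, a fluorine atom or an aminomethyl group on this same carbon would fall relative to amino and hydroxy. They also leave open whether amino and hydroxy would keep this order on the other carbons of the ring, or with a different group in place of the methoxy of the shared core.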